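Compound 2 to compound 4: a step from the limit

The source may report more compounds than this note shows. Statements on the series, on what has been measured and on what is new or still open speak of the compounds shown alone.

In a functional assay on THP-1 cells (Homo sapiens) for inhibition, read by sulforhodamine B assay, with a stated time of 48 h (on this read-out lower numbers stand for stronger inhibition and higher numbers for weaker inhibition), compound 1 (`COc1ccc(/C(=N/O)c2cccc3ccccc23)c(OC)c1OC`) gives > 20000 nM as a limit. Compound 2 (`COc1ccc(C(c2ccccc2O)c2cccc3ccccc23)c(OC)c1OC`) gives > 20000 nM as a limit too, so its standing is a limit and not a number. Compound 3 (`COc1ccc(/C(=N/OCC(=O)O)c2cccc3ccccc23)c(OC)c1OC`) gives > 20000 nM as a limit as well.

Compound 4 (`COc1ccc(C(OCc2ccc(C)cc2)c2cccc3ccccc23)c(OC)c1OC`) differs from compound 2 on a saturated chain carbon bound to two aromatic carbons ((4-methylbenzyl)oxy in place of 2-hydroxyphenyl on a saturated chain carbon bound to two aromatic carbons), with (4-methylbenzyl)oxy in place of 2-hydroxyphenyl. Among the measured compounds shown here, the only measured step (a step that the two limits leave unreadable from compound 1 to compound 3) has no readable size and lies elsewhere in the structure, so it offers no guide to size or direction. For the measured compounds named here, the series so far rests on the limit of > 20000 nM in this assay, at which 3 of the 3 values shown sit, and offers no measured gain to carry over. In this assay the expected step (a number no higher from compound 2 to compound 4 (the limit leaves the size open)) is none beyond the scatter, in either direction. For compound 4 the expected value is 20000 nM with an estimated range from 6000 nM to 40000 nM and a report as a limit is the likeliest outcome.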

Compound 4, half-maximal inhibitory concentration: > 20000 nM
Compound 4: only a limit was reported; the forecaster's own chance of this, stated with the estimate: 65%; the middle value lies on the limit itself.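

Compound 2 and compound 4 are both reported only as limits in this assay, and no step can be read between them. The compounds shown leave open whether any change on the shared core gives a measurable value, as all results so far sit at one limit: the limit of > 20000 nM in this assay, at which 4 of the 4 values shown sit.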